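From naphthalen-1-yl to 4-chlorophenyl on a methoxy compound

This account rests on a few compounds, and the source may have more. Where it says the series, first, only, none or still open, it means among the compounds named here.

For the measured compounds named here, in a functional assay on HL-60 cells (Homo sapiens) for inhibition, read by CCK-8 assay, with a stated time of 48 h, tested at 20 uM (a lower number here means less inhibition of growth, a higher number more inhibition of growth at the concentration tested), compound 2 (`COc1ccc(S(=O)(=O)Oc2ccccc2/C=C(\C#N)C(=O)Nc2nnc(Cc3cccc4ccccc34)s2)cc1`) gives 98%, the highest of the three numbers measured so far. Compound 1 (`Cc1ccc(S(=O)(=O)Oc2ccccc2/C=C(\C#N)C(=O)Nc2nnc(Cc3cccc4ccccc34)s2)cc1`) gives 19%, and compound 3 (`N#C/C(=C\c1ccccc1OS(=O)(=O)c1ccc(F)cc1)C(=O)Nc1nnc(Cc2cccc3ccccc23)s1`) gives 12%. Methoxy in place of methyl brings a number 79 percentage points higher from compound 1 to compound 2 (beyond the scatter), fluoro in place of methoxy brings a number 86 percentage points lower from compound 2 to compound 3 (beyond the scatter), and fluoro in place of methyl brings only a number 7 percentage points lower from compound 1 to compound 3 (within the scatter).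

Compound 4 (`COc1ccc(S(=O)(=O)Oc2ccccc2/C=C(\C#N)C(=O)Nc2nnc(Cc3ccc(Cl)cc3)s2)cc1`) keeps the methoxy group of compound 2 and changes elsewhere: 4-chlorophenyl in place of naphthalen-1-yl on a saturated chain carbon bound to an aromatic carbon, with 4-chlorophenyl in place of naphthalen-1-yl on a saturated chain carbon bound to an aromatic carbon. Going by the values given here, no measured step touches that place, so the two large steps bear on it only indirectly, showing that one change in this small set can move the number far. Compound 2 at 98% leaves little room upward, so any real move is expected to be downward. The expected change is a number 40 percentage points lower from compound 2 to compound 4 (beyond the scatter), an estimate that carries wide uncertainty. The estimated value for compound 4 is 58%, with an expected range from 15% to 98%.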

Compound 4, percent growth inhibition at one concentration: 99%
Beside the measured number, compound 4's estimate is 41 percentage points below it; the whole stated range lies below it.
By their numbers in this assay, from the lowest: compounds 3 and 1 (each within the scatter of the next); then compounds 2 and 4 (each within the scatter of the next).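

In this assay, 4-chlorophenyl in place of naphthalen-1-yl gives a number 1 percentage points higher from compound 2 to compound 4 (within the scatter), so with the methoxy group held fixed, this first change on a saturated chain carbon bound to an aromatic carbon leaves the two numbers indistinguishable, even though one six-membered aromatic ring and three heavy atoms are gone. Unlike the large steps among the earlier compounds, it shows that the naphthalen-1-yl group is not required for a number near the top of this read-out, although a single concentration so close to the ceiling could hide a real difference between compound 2 and compound 4. Nothing in the data given explains this result.

The compounds shown pair 4-chlorophenyl only with methoxy, so whether it would change the much lower numbers of the methyl and fluoro compounds remains open. Also open, on these data alone, is how a carboxylic acid or an amine on this benzyl group would behave.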